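Aryl swap at the limit: compound 3 to compound 4

The source may hold more compounds than are shown below. What is called first, only, known or untested is meant among the compounds shown, and "the series" means these compounds.

Measured so far in a functional assay on ECa-109 cells (Homo sapiens) for cytotoxicity, read by MTT assay, with a stated time of 48 h (a lower number here means a stronger inhibitor, a higher number a weaker inhibitor), each entry a limit and not a number:
Compound 1 `COc1ccc(-c2c[nH]c(=O)n2-c2cc(OC)c(OC)c(OC)c2)cc1[N+](=O)[O-]`: limit of > 50000 nM
Compound 2 `COc1cc(-n2c(-c3ccccc3)cn(C(C)=O)c2=O)cc(OC)c1OC`: limit of > 50000 nM
Compound 3 `COc1cc(-n2c(-c3ccc([N+](=O)[O-])cc3)cn(C(C)=O)c2=O)cc(OC)c1OC`: limit of > 50000 nM

Compound 3 gives only a limit, > 50000 nM, and so offers no number to start from. The same holds across the whole set: the limit of > 50000 nM in this assay, at which 3 of the 3 values shown sit.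

The next compound is compound 4 `COc1cc(-n2c(-c3ccc(F)cc3F)cn(C(C)=O)c2=O)cc(OC)c1OC`. Here 2,4-difluorophenyl replaces 4-nitrophenyl on an aromatic carbon of the five-membered aromatic ring, while the rest of the structure stays the same: 2,4-difluorophenyl in place of 4-nitrophenyl on an aromatic carbon.

For the measured compounds named here, only one measured step bears on this change, and it concerns the same aryl group: a step that the two limits leave unreadable from compound 2 to compound 3. It has no readable size, so it gives neither a size nor a direction to carry over. Going by the values given here, nothing measured so far shows a number in this assay, so the working expectation is that compound 4 also stays at the limit, with no readable change. The expected step is a number no higher from compound 3 to compound 4 (the limit leaves the size open). For compound 4 the estimated value is 50000 nM, with an expected range from 12000 nM to 100000 nM.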

Compound 4, half-maximal inhibitory concentration: > 50000 nM
Compound 4: a limit, no number; the forecaster's own chance of this, stated with the estimate: 75%; the middle value lies on the limit itself.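

In this assay compound 4 gives > 50000 nM, a limit and not a number. The steps from compound 2 and from compound 3 to compound 4 cannot be read, since each joins two limits. The compounds shown leave open whether any change on the shared core gives a readable number at all: the limit of > 50000 nM in this assay, at which 4 of the 4 values shown sit.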